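This account rests on a few compounds, and the source may have more. Where it says the series, first, only, none or still open, it means among the compounds named here.

The series shares the core of compound 1 `CC(C)(C)Cc1c(-c2cccc(F)c2F)sc(N)c1C(=O)c1ccc(Cl)cc1`, which in an assay on CHO cells for displacement of a labelled ligand from adenosine receptor A3 (Homo sapiens), read by scintillation counting, tested at 10 uM (on this read-out lower numbers stand for less inhibition and higher numbers for more inhibition at the one concentration tested (going by the name of the read-out)), gives 1%. Compound 2 `CC(C)(C)Cc1c(-c2ccc(Cl)cc2)sc(N)c1C(=O)c1ccc(Cl)cc1` gives 1%, and compound 3 `COc1ccccc1-c1sc(N)c(C(=O)c2ccc(Cl)cc2)c1CC(C)(C)C` gives 1%, so compound 3 stands level with both at the digits shown. Across the set the substituent on an aromatic carbon is exchanged without measurable effect: no change at the digits printed from compound 1 to compound 2 (within the scatter), no change at the digits printed from compound 1 to compound 3 (within the scatter) and no change at the digits printed from compound 2 to compound 3 (within the scatter). Compound 4 `CC(C)(C)Cc1c(-c2ccccc2)sc(N)c1C(=O)c1ccc(Cl)cc1` continues this exchange; relative to compound 3 the difference is hydrogen in place of methoxy on an aromatic carbon. All three measured steps bear on it, each within the scatter, so no step beyond the scatter is expected in this assay, the estimated size being a number 1 percentage points higher from compound 3 to compound 4 (within the scatter). Compound 4 is therefore expected to give 2%, with a range from -8% to 12%.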

Compound 4, a percentage reported as inhibition, at one concentration (the size of the read-out at that concentration, not a potency): 1%
Beside the measured number, compound 4's estimate is 1 percentage points above it; the range from low to high includes it.
By their numbers in this assay, from the lowest: compounds 1, 2, 3 and 4 (each within the scatter of the next).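

Bare phenyl, with hydrogen in place of any substituent, falls in line with the substituted rings in this assay: the reading shows no change at the digits printed from compound 3 to compound 4 (within the scatter) and no change at the digits printed from compound 2 to compound 4 (within the scatter) and also no change at the digits printed from compound 1 to compound 4 (within the scatter) in this series. Earlier compounds compared only substituted rings with one another; now methoxy, chloro and 2,3-difluoro are each indistinguishable from hydrogen at this position. No available data offer an explanation for this flat result.

On these data alone, whether an amine, a carboxylic acid or a longer chain at this position would move the reading remains open. As far as these compounds go, the effect of changes elsewhere on the shared core also remains open.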